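Replacing a Dimethoxyphenyl with a Difluorophenyl on the Carbonyl

The compounds below may be only part of what the source reports. "The series", "measured", "known", "first", "only" and "open" are said of these compounds alone.

Two measured compounds share a common core and differ only in the group bonded to a carbonyl carbon. Compound 1 `COc1cc(-c2cc(/C=C/C(=O)c3ccc(N)cc3)[nH]n2)cc(OC)c1OC` carries a 4-aminophenyl there, whereas compound 2 `COc1ccc(C(=O)/C=C/c2cc(-c3cc(OC)c(OC)c(OC)c3)n[nH]2)cc1OC` carries a 3,4-dimethoxyphenyl. In a functional assay on ACHN cells (Homo sapiens) for cytotoxicity, read by sulforhodamine B assay, with a stated time of 48 h, tested at 1 uM (on this read-out higher numbers stand for a weaker effect at the one concentration tested and lower numbers for a stronger effect), compound 1 gives 79%, and compound 2 gives 91%. For the measured compounds named here, the one recorded step, a number 12 percentage points higher from compound 1 to compound 2 (beyond the scatter), places compound 2 at the weaker end of the two numbers, separated from compound 1 by more than the scatter.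

Compound 3 `COc1cc(-c2cc(/C=C/C(=O)c3ccc(F)c(F)c3)[nH]n2)cc(OC)c1OC` has not been measured. Relative to compound 2 its change is 3,4-difluorophenyl in place of 3,4-dimethoxyphenyl on a carbonyl carbon. Going by the values given here, the only measured step that bears on this is a number 12 percentage points higher from compound 1 to compound 2 (beyond the scatter), which shows that swapping the group on this carbonyl carbon can shift the read-out by a modest amount. Among the compounds with values here, no measured pair involves a 3,4-difluorophenyl, so the direction of any shift cannot be read from the data, and the expected step of a number 3 percentage points lower from compound 2 to compound 3 (within the scatter) is estimated to lie within the scatter. Compound 3 is therefore expected to give 88% in this assay, with a range from 72% to 100%.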

Compound 3, a percentage reported as activity, at one concentration (the size of the read-out at that concentration, not a potency): 100%
For compound 3 the middle estimate is 12 percentage points below the measured one, within the range that was stated.
By their numbers in this assay, from the lowest: compound 1; then compounds 2 and 3 (each within the scatter of the next).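

In this assay, the step of a number 9 percentage points higher from compound 2 to compound 3 (within the scatter) does not separate the 3,4-difluorophenyl from the 3,4-dimethoxyphenyl on this carbonyl carbon, so exchanging these two groups shows no clear effect on the read-out. The 4-aminophenyl group gives a different picture, with the step of a number 21 percentage points higher from compound 1 to compound 3 (beyond the scatter) joining the earlier gap to compound 2 and leaving compound 1 with the strongest effect of the three at the single concentration tested. No measurement shown here explains why compound 1 stands apart from the other two.

Three groups cannot show whether the stronger effect depends on the amine itself, and a plain phenyl, a 4-hydroxyphenyl or a 4-acetamidophenyl on the same carbonyl carbon would help to settle that question. A read-out at one concentration also leaves open how compound 1 would behave at other concentrations, and whether compound 2 and compound 3 would remain indistinguishable at a higher one.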